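Replacing the Furan Arm: Cytotoxicity of Compound 4

The source may report more compounds than this note shows. Statements on the series, on what has been measured and on what is new or still open speak of the compounds shown alone.

Compound 1 `Cc1cc(C)cc(Cc2ccc3c(NCCCNCc4ccco4)ccnc3c2)c1`: 6270 nM
Compound 2 `COc1cccc(Oc2ccc3c(NCCCNCc4ccco4)ccnc3c2)c1`: 15500 nM
Compound 3 `Clc1ccc(Oc2ccc3c(NCCCNCc4ccco4)ccnc3c2)cc1`: 7800 nM

In an ADME assay on HepG2 cells (Homo sapiens) for cytotoxicity, read by luminescence, CellTiter-Glo and ATP content, with a stated time of 72 h (a lower number here means that less compound is needed, a higher number that more compound is needed for the effect), compound 3 gives the second highest of the three numbers. The step of a 1.2-fold higher number from compound 1 to compound 3 (0.09 log units; within the scatter) lies within the scatter, as does a 2.0-fold lower number from compound 2 to compound 3 (0.30 log units; within the scatter); only a 2.5-fold higher number from compound 1 to compound 2 (0.39 log units; beyond the scatter) reaches beyond it. All three of these steps alter the group on the aromatic carbon of the shared core, and none touches the amine end of the chain.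

Compound 4 `COc1cccc(CNCCCNc2ccnc3cc(Oc4ccc(Cl)cc4)ccc23)c1O` differs from compound 3 at that untouched end: 2-hydroxy-3-methoxyphenyl in place of furan-2-yl on a saturated chain carbon bound to an amine nitrogen. Among the compounds with values here, no measured step bears on this change, so the data give no direction for it; the three measured numbers lie close together. Compound 4 is therefore expected to give about 8000 nM, between 3000 nM and 25000 nM. The expected step of a 1.0-fold higher number from compound 3 to compound 4 (0.01 log units; within the scatter) is estimated to stay within the scatter.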

Compound 4, half-maximal effective concentration: 5700 nM
Compound 4: the middle estimate sits 1.4-fold (0.15 log units) above what was measured, and the stated range covers the measured number.
By their numbers in this assay, from the lowest: compounds 4, 1, 3 and 2 (each within the scatter of the next, the first and the last beyond it).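

Compound 4 is the first compound shown with a change at the amine end of the chain, and in this assay 2-hydroxy-3-methoxyphenyl in place of furan-2-yl gives a 1.4-fold lower number from compound 3 to compound 4 (0.14 log units; within the scatter), so this exchange of a five-membered ring for a six-membered aromatic ring carrying a hydrogen-bond donor stays within the scatter. Nothing measured here explains this outcome.

The compounds shown leave open whether the hydroxy or the methoxy group matters, and how an unsubstituted phenyl or a pyridin-2-yl would compare. The new arm also appears only with the 4-chlorophenoxy group on the core.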